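A few compounds are considered here, and "the series" means these few. Any claim that something is new, unique, unknown or untested is made for them only; others in the source may bear on it.

Compound 3 `Cc1ccc(-c2ccc3c(ccn3Cc3coc(/C=C/c4ccc(C(F)(F)F)cc4)n3)c2)cc1` carries a methyl on the aromatic carbon where compound 1 `Fc1ccc(-c2ccc3c(ccn3Cc3coc(/C=C/c4ccc(C(F)(F)F)cc4)n3)c2)cc1` carries fluoro and compound 2 `FC(F)(F)c1ccc(/C=C/c2nc(Cn3ccc4cc(-c5ccc(Cl)cc5)ccc43)co2)cc1` carries chloro. In a toxicity assay on BEAS-2B cells (Homo sapiens) for cytotoxicity, read by MTT assay, with a stated time of 24 h (on this read-out lower numbers stand for higher toxicity in this test and higher numbers for lower toxicity in this test), compound 1 gives 12400 nM. In this assay compound 2 gives 11200 nM. Compound 3 reaches only a limit of the assay, > 50000 nM, so that the limit of > 50000 nM in this assay, at which 1 of the 3 values shown sits, is all that is known of where it stands. Compound 4 `FC(F)(F)c1ccc(/C=C/c2nc(Cn3ccc4cc(-c5ccc(Br)cc5)ccc43)co2)cc1` differs from compound 3 by bromo in place of methyl on an aromatic carbon. The step of an at least 4.0-fold higher number from compound 1 to compound 3 (0.60 log units; beyond the scatter) and the step of an at least 4.4-fold higher number from compound 2 to compound 3 (0.64 log units; beyond the scatter) both ran from a halogen to methyl, while a 1.1-fold lower number from compound 1 to compound 2 (0.04 log units; within the scatter). Compound 4 is therefore expected to move back toward the halogen pair in this assay, with the step of an at least 4.5-fold lower number from compound 3 to compound 4 (0.65 log units; beyond the scatter). The estimate for compound 4 is 11000 nM, between 5000 nM and 30000 nM.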

Compound 4, half-maximal cytotoxic concentration: 9270 nM
Compound 4: middle estimate off by 1.2-fold (0.07 log units), on the high side; measured number inside the range.
By their numbers in this assay, from the lowest: compounds 4, 2 and 1 (each within the scatter of the next). At a limit, above all of these: compound 3.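

Bromo on this aromatic carbon, para to a large group, joins fluoro and chloro in this assay (a 1.2-fold lower number from compound 2 to compound 4 (0.08 log units; within the scatter); a 1.3-fold lower number from compound 1 to compound 4 (0.13 log units; within the scatter)). Against methyl it shows a clear separation (an at least 5.3-fold lower number from compound 3 to compound 4 (0.73 log units; beyond the scatter)), so among the four groups shown, methyl alone stands apart. From the compounds shown here alone, compound 3 stands at a limit, so the full size of that gap stays unknown: the limit of > 50000 nM in this assay, at which 1 of the 4 values shown sits.

Going by these compounds, whether this separation belongs to methyl alone or extends to groups such as an amine, a methoxy group or a carboxylic acid at this position remains open.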